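Swapping the group on a sulfonamide nitrogen: compound 3 to compound 4

The source may hold more compounds than are shown below. What is called first, only, known or untested is meant among the compounds shown, and "the series" means these compounds.

compound 1 `O=S(=O)(Nc1ccc(F)c(Cl)c1)c1ccc(-c2cnc(C3CC3)o2)cc1` gives 73700 nM
compound 2 `Cc1cc(NS(=O)(=O)c2ccc(-c3cnc(C4CC4)o3)cc2)ccc1Cl` gives 33400 nM
compound 3 `O=S(=O)(Nc1ccc(F)cc1F)c1ccc(-c2cnc(C3CC3)o2)cc1` gives 66100 nM

These values come from a functional assay on cells (leukaemia cell line, Homo sapiens) for inhibition, read by sulforhodamine B assay, with a stated time of 48 h (a lower number here means a stronger inhibitor of growth, a higher number a weaker inhibitor of growth), and the three compounds differ only in the group on a sulfonamide nitrogen. Compound 3 stands within the scatter of both other compounds, as a 1.1-fold lower number from compound 1 to compound 3 (0.05 log units; within the scatter) and a 2.0-fold higher number from compound 2 to compound 3 (0.30 log units; within the scatter) show. Only a 2.2-fold lower number from compound 1 to compound 2 (0.34 log units; beyond the scatter) goes beyond the scatter, and it is modest.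

Compound 4 `O=S(=O)(Nc1cc(Cl)ccc1Cl)c1ccc(-c2cnc(C3CC3)o2)cc1` differs from compound 3 in one place: 2,5-dichlorophenyl in place of 2,4-difluorophenyl on a sulfonamide nitrogen. It carries 2,5-dichlorophenyl in place of 2,4-difluorophenyl on a sulfonamide nitrogen. Among the measured compounds shown here, no measured compound carries the 2,5-dichlorophenyl group, so no step tests this change directly. For the measured compounds named here, the three measured steps are all swaps at this same place and are the only guide. The largest of them is a 2.2-fold lower number from compound 1 to compound 2 (0.34 log units; beyond the scatter), so no step beyond the scatter is expected in this assay, in either direction. The expected step is a 1.3-fold lower number from compound 3 to compound 4 (0.10 log units; within the scatter). Compound 4 is estimated at 52000 nM, with an expected range from 28000 nM to 100000 nM.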

Compound 4, concentration for total growth inhibition: > 100000 nM
Compound 4 ended at the assay's limit; the forecaster's own chance of this, stated with the estimate: 15%; middle value at least 1.9-fold (0.28 log units) from the limit.
By their numbers in this assay, from the lowest: compounds 2, 3 and 1 (each within the scatter of the next, the first and the last beyond it). At a limit, above all of these: compound 4.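

In this assay compound 4 gives > 100000 nM, which is a limit of the assay and not a number, and it is the only compound shown to end there: the limit of > 100000 nM in this assay, at which 1 of the 4 values shown sits. Even so, the result shows that a swap at this sulfonamide nitrogen can separate 2,5-dichlorophenyl from 4-chloro-3-methylphenyl, with an at least 2.9-fold higher number from compound 2 to compound 4 (0.47 log units; beyond the scatter), and this makes 2,5-dichlorophenyl the weaker growth inhibitor of that pair. The other two comparisons give only floors within the scatter, an at least 1.5-fold higher number from compound 3 to compound 4 (0.17 log units; that floor lies within the scatter) and an at least 1.3-fold higher number from compound 1 to compound 4 (0.13 log units; that floor lies within the scatter), so they do not yet separate 2,5-dichlorophenyl from 2,4-difluorophenyl or from 3-chloro-4-fluorophenyl.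

From the compounds shown here alone, how far compound 4 lies past its limit stays open, and with it the true size of all three steps. All four groups shown are substituted phenyl rings carrying halogen, and the lowest number among them, from compound 2, is still 33400 nM, so it remains open whether a phenyl ring bearing a methoxy group, an amine or a carboxylic acid at this nitrogen would give a markedly lower number.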